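Swapping One Small Group on a Shared Core

A few compounds are considered here, and "the series" means these few. Any claim that something is new, unique, unknown or untested is made for them only; others in the source may bear on it.

Of the compounds shown here, three have been measured so far in a functional assay, with a stated time of 150 min; on this read-out lower numbers stand for stronger inhibition and higher numbers for weaker inhibition. In that read-out compound 1 `COc1ccc(-c2nc(SC)n(C)c(=O)c2C#N)cc1` gives 73 ug/mL. Compound 2 `COc1ccc(-c2nc(NN)n(C)c(=O)c2C#N)cc1` carries an aminoamino group where compound 1 carries methylsulfanyl; in this assay compound 2 gives 56 ug/mL. The change from compound 2 to compound 1 is methylsulfanyl in place of aminoamino on an aromatic carbon and it made a 1.3-fold higher number from compound 2 to compound 1 (0.12 log units; within the scatter).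

Compound 3 `COc1cccc(-c2nc(NN)n(C)c(=O)c2C#N)c1OC` is built on a core that is not the same as the core of compound 2; the difference between the two cores is not broken down here. In this assay, going by the values given here, compound 3 gives 54 ug/mL, and the three numbers measured so far all lie within the usual scatter of one another.

Compound 4 `COc1cccc(-c2nc(SC)n(C)c(=O)c2C#N)c1OC` has not yet been measured. It relates to compound 3 as compound 1 relates to compound 2: methylsulfanyl in place of aminoamino on an aromatic carbon. Around the place, the two changes differ only in that the group meta to it is once a group of 8 heavy atoms and once a large group, so this is the same kind of change rather than the same change.

Compound 4 is expected to give about 70 ug/mL, somewhere between 40 ug/mL and 120 ug/mL, because a 1.3-fold higher number from compound 2 to compound 1 (0.12 log units; within the scatter) came from the same kind of change. This estimate means an expected step of a 1.3-fold higher number from compound 3 to compound 4 (0.11 log units; within the scatter), which would stay within the scatter.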

Compound 4, half-maximal inhibitory concentration: 67 ug/mL
Beside the measured number, compound 4's estimate is 1.0-fold (0.02 log units) above it; measured number inside the range.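

Placing methylsulfanyl where aminoamino stood on the core of compound 3 gives, in this assay, a 1.2-fold higher number from compound 3 to compound 4 (0.09 log units; within the scatter). Set beside the earlier step on the other core, the same swap reads alike on both cores: the same change on two cores in this assay, a 1.3-fold higher number (0.12 log units; within the scatter) from compound 2 to compound 1 and a 1.2-fold higher number (0.09 log units; within the scatter) from compound 3 to compound 4, 1.1-fold (0.02 log units) apart, within the scatter of two such steps. This shows that, for these two cores in this one assay, the swap gives a step too small to tell from repeat-to-repeat variation on either core, so the core makes no detectable difference to its outcome, but it does not show that the two groups are equivalent, since a result that stays within the scatter can hide a small real difference and says nothing about other cores or other read-outs.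

On these data alone, only aminoamino and methylsulfanyl appear at this place on the aromatic carbon between two ring nitrogen atoms, so it remains open whether a different group there, such as a morpholine, a longer chain like butylsulfanyl or a carboxylic acid, would move the number beyond the scatter. The pairs shown also leave open whether the close agreement between the two steps would hold on a core with a different group on the outer ring, such as a chlorine atom or a hydroxyl group in place of methoxy.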